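Benzyloxy series: thiophene in place of phenyl

This account rests on a few compounds, and the source may have more. Where it says the series, first, only, none or still open, it means among the compounds named here.

Measured compounds:
- compound 1, `Cc1nc2c(OCc3ccccc3)cccn2c1N`, 97%
- compound 2, `CCCCc1nc2c(OCc3ccccc3)cccn2c1N`, 45%
- compound 3, `Cc1nc2c(OCc3ccc(C(F)(F)F)cc3)cccn2c1N`, 0%

In a functional assay on the whole organism with Canis familiaris (Canis lupus familiaris) as the target, at a dose of 2 mg/kg by the intravenous route (on this read-out higher numbers stand for a stronger effect at the one dose given and lower numbers for a weaker effect), compound 1 gives 97% and stands highest of the three numbers. Its steps to the others are both beyond the scatter: a number 52 percentage points lower from compound 1 to compound 2 (beyond the scatter), and a number 97 percentage points lower from compound 1 to compound 3 (beyond the scatter). Compound 2 is the nearer of the two, compound 3 the further.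

Compound 4, `Cc1nc2c(OCc3cccs3)cccn2c1N`, has not been measured. It differs from compound 1 in one place: thiophen-2-yl in place of phenyl on a saturated chain carbon bound to an oxygen on an aromatic ring.

Neither measured step touches this place. The step to compound 2 alters the saturated chain carbon bound to an aromatic carbon, and the step to compound 3 alters an aromatic carbon of the phenyl that is now exchanged. The step to compound 3 shows that a change on the phenyl ring itself can remove the whole effect, so the exchange of phenyl for thiophen-2-yl is not assumed to be neutral. A step in this assay that is downward but smaller than either of the two known steps is expected: a number 22 percentage points lower from compound 1 to compound 4 (beyond the scatter). For compound 4 the expected value is 75%, in the range 35% to 100%.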

Compound 4, a percentage reported as inhibition, in the whole organism at one dose (the size of the read-out at that dose, not a potency): 77%
For compound 4 the middle estimate is 2 percentage points below the measured one; low and high end bracket the measured number.
By their numbers in this assay, from the lowest: compound 3; then compound 2; then compound 4; then compound 1.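

In this assay thiophen-2-yl in place of phenyl gives a number 20 percentage points lower from compound 1 to compound 4 (beyond the scatter) and so shows that the phenyl on the saturated chain carbon bound to an oxygen on an aromatic ring can be exchanged for a five-membered aromatic ring with 1 hetero atom while a clear effect remains at the one dose given. For the compounds shown here, until this result, the only change touching this ring was trifluoromethyl, with a number 97 percentage points lower from compound 1 to compound 3 (beyond the scatter) as the outcome, so a change at this ring does not by itself remove the effect, although the exchange still costs more than the usual scatter. No measurement at hand accounts for the drop seen with thiophen-2-yl.

The compounds shown leave open whether thiophen-3-yl, furan-2-yl or a pyridine ring would hold the read-out as thiophen-2-yl does, and whether fluorine or methoxy on the phenyl would fare better than trifluoromethyl. They also leave open how thiophen-2-yl behaves together with the longer butyl chain of compound 2, and, with a single dose as the only read-out, how these compounds compare in potency.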